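This account rests on a few compounds, and the source may have more. Where it says the series, first, only, none or still open, it means among the compounds named here.

Values in a functional assay on MCF7 cells (Homo sapiens) for antiproliferative activity; a lower number here means a stronger inhibitor, a higher number a weaker inhibitor
- compound 1 (`CC(C)=CCc1cc(C(=O)Nc2cc3ccc(OCCCNCCO)c(C)c3oc2=O)ccc1O`) gives 1560 nM
- compound 2 (`CC(C)=CCc1cc(C(=O)Nc2cc3ccc(OCCCNC4CCCCC4)c(C)c3oc2=O)ccc1O`) gives 1070 nM

Compound 2 stands within the scatter of compound 1, with no order between the two. Compound 3 (`CC(C)=CCc1cc(C(=O)Nc2cc3ccc(OCCCNCc4ccccc4)c(C)c3oc2=O)ccc1O`) carries benzyl in place of cyclohexyl on an amine nitrogen as its one difference: benzyl in place of cyclohexyl on an amine nitrogen. For the measured compounds named here, the only measured change on that nitrogen, cyclohexyl in place of 2-hydroxyethyl, was small (a 1.5-fold lower number from compound 1 to compound 2 (0.16 log units; within the scatter)), so no step beyond the scatter is expected in this assay here. The expected step, a 1.1-fold higher number from compound 2 to compound 3 (0.05 log units; within the scatter), is an estimate only. For compound 3 the estimated value is 1200 nM, with an expected range from 500 nM to 2800 nM as its limits.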

Compound 3, half-maximal inhibitory concentration: 910 nM
Estimate against measurement, compound 3: 1.3-fold (0.12 log units) above; the range from low to high includes it.
By their numbers in this assay, from the lowest: compounds 3, 2 and 1 (each within the scatter of the next).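

In this assay, an aromatic ring on this amine nitrogen gives a number within the scatter of the saturated ring, benzyl in place of cyclohexyl (a 1.2-fold lower number from compound 2 to compound 3 (0.07 log units; within the scatter)). Phenyl in place of hydroxymethyl on the saturated chain carbon bound to that nitrogen also stays within the scatter (a 1.7-fold lower number from compound 1 to compound 3 (0.23 log units; within the scatter)), so the three substituents cannot be told apart here. No measurement bears on why this position responds so little.

Open, as far as these compounds go, is whether a fluorobenzyl or a carboxylic acid on this nitrogen would give a step beyond the scatter. A tertiary amine such as dimethylamino also remains to be compared.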